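A bromo substituent on the benzyl ring of compound 1

The source may report more compounds than this note shows. Statements on the series, on what has been measured and on what is new or still open speak of the compounds shown alone.

Compound 1 `COc1cc(OC)c(-c2coc3cc(OCc4ccccc4)ccc3c2=O)cc1OC` has the lowest of the two numbers given in a functional assay on B16 cells (Mus musculus) for antiproliferative activity, read by MTT assay, with a stated time of 24 h (a higher number here means a weaker inhibitor, a lower number a stronger inhibitor), where compound 1 gives 2330 nM. Its nearest neighbour is compound 3 `COc1cc(OC)c(-c2coc3cc(OCc4ccc(Cl)cc4)ccc3c2=O)cc1OC`, which gives 2400 nM; that step a 1.0-fold higher number from compound 1 to compound 3 (0.01 log units; within the scatter) is within the scatter. Compound 2 `COc1cc(OC)c(-c2coc3cc(OCc4ccc([N+](=O)[O-])cc4)ccc3c2=O)cc1OC` reaches only the limit of this assay (the limit of > 10000 nM in this assay, at which 1 of the 3 values shown sits), and for compound 2 the result is > 10000 nM. The step of an at least 4.2-fold higher number from compound 1 to compound 2 (0.63 log units; beyond the scatter) is therefore at least modest. Compound 4 `COc1cc(OC)c(-c2coc3cc(OCc4ccccc4Br)ccc3c2=O)cc1OC` differs from compound 1 by bromo in place of hydrogen on an aromatic carbon. The chloro step bears most closely on this change and showed no movement; the nitro step is the only one beyond the scatter. Compound 4 is therefore expected to sit close to compound 1, with a step of a 1.2-fold higher number from compound 1 to compound 4 (0.08 log units; within the scatter), and an estimated value of 2800 nM, ranging from 1200 nM to 7000 nM.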

Compound 4, half-maximal inhibitory concentration: 8900 nM
Beside the measured number, compound 4's estimate is 3.2-fold (0.50 log units) below it, outside the stated range (above it).
By their numbers in this assay, from the lowest: compounds 1 and 3 (each within the scatter of the next); then compound 4. At a limit, above all of these: compound 2.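

In this assay, bromo in place of hydrogen on an aromatic carbon gives a 3.8-fold higher number from compound 1 to compound 4 (0.58 log units; beyond the scatter). The silent chloro step of compound 3 therefore does not extend to compound 4, and 2-bromophenyl in place of 4-chlorophenyl gives a 3.7-fold higher number from compound 3 to compound 4 (0.57 log units; beyond the scatter). The remaining step, an at least 1.1-fold lower number from compound 2 to compound 4 (0.05 log units; that floor lies within the scatter), is only a floor and does not order the two compounds. Compound 2 stands at a limit of the assay: the limit of > 10000 nM in this assay, at which 1 of the 4 values shown sits.

Halogen and place change together between compound 3 and compound 4, so it stays open whether 2-chlorophenyl or 4-bromophenyl would sit with compound 3 or with compound 4. As far as these compounds go, how an amine on the benzyl ring would read also remains open.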